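Compound 3 to compound 4: one group exchanged

The compounds below may be only part of what the source reports. "The series", "measured", "known", "first", "only" and "open" are said of these compounds alone.

Measured so far (a functional assay on SH-SY5Y cells (Homo sapiens) for antiproliferative activity, read by MTT assay, with a stated time of 72 h; on this read-out higher numbers stand for weaker inhibition and lower numbers for stronger inhibition)
- compound 1 (`COc1cc2c(Nc3ccc(C#N)cc3)ncnc2cc1OCCCN(C)C`): 34900 nM
- compound 2 (`CCN(CC)CCCOc1cc2ncnc(Nc3ccc(C#N)cc3)c2cc1OC`): > 100000 nM (a limit)
- compound 3 (`COc1cc2c(Nc3ccc(C#N)cc3)ncnc2cc1OCCCN1CCCCC1CCO`): > 100000 nM (a limit)

For compound 3 the reading > 100000 nM is a limit of the assay and not a number. Compound 4 (`COc1cc2c(Nc3ccc(C#N)cc3)ncnc2cc1OCCCN1CCN(C)CC1`) exchanges one group of compound 3 on a saturated chain carbon, three bonds along the chain from an oxygen on an aromatic ring: 4-methylpiperazin-1-yl comes in place of 2-(2-hydroxyethyl)piperidin-1-yl (4-methylpiperazin-1-yl in place of 2-(2-hydroxyethyl)piperidin-1-yl on a saturated chain carbon, three bonds along the chain from an oxygen on an aromatic ring).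

Three measured steps change this same place. Two of them, an at least 2.8-fold higher number from compound 1 to compound 2 (0.45 log units; beyond the scatter) and an at least 2.8-fold higher number from compound 1 to compound 3 (0.45 log units; beyond the scatter), lie beyond the scatter, and each ends at a limit, so each gives only a minimum size. The third, a step that the two limits leave unreadable from compound 2 to compound 3, tells nothing about size. Both readable steps leave compound 1 for a higher number, and the limit of > 100000 nM in this assay, at which 2 of the 3 values shown sit, shows how little room remains for comparison.

Given an at least 2.8-fold higher number from compound 1 to compound 3 (0.45 log units; beyond the scatter), compound 4 is expected to stay weak in this assay, with only compound 1 as a numerical guide. The expected change is an at least 1.6-fold lower number from compound 3 to compound 4 (0.22 log units; that floor lies within the scatter), a modest move towards a lower number at best. For compound 4 the estimated value is 60000 nM, with an expected range from 20000 nM to 150000 nM, and a reading at the limit remains quite possible.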

Compound 4, half-maximal inhibitory concentration: 13000 nM
For compound 4 the middle estimate is 4.6-fold (0.66 log units) above the measured one, and the stated range ends above it.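

In this assay, the earlier exchanges at this place led only away from the dimethylamino group of compound 1, towards higher numbers. The 4-methylpiperazin-1-yl group now gives a 2.7-fold lower number from compound 1 to compound 4 (0.43 log units; beyond the scatter), so this place on the chain can also move the number down, and this is the first step shown here with a real number at both ends. The other two steps, an at least 7.6-fold lower number from compound 3 to compound 4 (0.88 log units; beyond the scatter) and an at least 7.6-fold lower number from compound 2 to compound 4 (0.88 log units; beyond the scatter), both start from a limit of the assay and so give only a minimum size, which leaves the distance from the two weaker compounds bounded rather than known: the limit of > 100000 nM in this assay, at which 2 of the 4 values shown sit.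

The compounds shown leave open whether the gain goes with the six-membered ring itself, with its second nitrogen or with the methyl group on that nitrogen, and plain piperidin-1-yl, morpholin-4-yl or unsubstituted piperazin-1-yl groups at this place would help to separate these possibilities. They also leave open whether 4-methylpiperazin-1-yl would keep its advantage over dimethylamino on a shorter or longer chain.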